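Swapping cyclobutyl for tert-butyl on the shared core

The source may report more compounds than this note shows. Statements on the series, on what has been measured and on what is new or still open speak of the compounds shown alone.

Measured so far:
compound 1, `CCCc1ccc(S(=O)(=O)NC(=O)OCCC(F)(F)C(F)(F)F)c(-c2ccc(Cn3c(C(C)(C)C)nc4ccccc43)cc2)c1`: 6 nM
compound 2, `CCCCOC(=O)NS(=O)(=O)c1ccc(CCC)cc1-c1ccc(Cn2c(-c3nccs3)nc3ccccc32)cc1`: 5.1 nM
compound 3, `CCCCOC(=O)NS(=O)(=O)c1ccc(CCC)cc1-c1ccc(Cn2c(C3CCC3)nc3ccccc32)cc1`: 12 nM

In an assay on membranes from HEK293 cells for displacement of a labelled ligand from Type-2 angiotensin II receptor (Homo sapiens), read by radioligand binding (on this read-out lower numbers stand for stronger inhibition and higher numbers for weaker inhibition), compound 3 gives the highest number of the three. Its gap to compound 2 is beyond the scatter, as the change a 2.4-fold higher number from compound 2 to compound 3 (0.37 log units; beyond the scatter) shows; its gap to compound 1 lies within the scatter.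

Compound 4, `CCCCOC(=O)NS(=O)(=O)c1ccc(CCC)cc1-c1ccc(Cn2c(C(C)(C)C)nc3ccccc32)cc1`, differs from compound 3 by tert-butyl in place of cyclobutyl on an aromatic carbon. Among the measured compounds shown here, no measured step makes exactly this change; the only step at this position, a 2.4-fold higher number from compound 2 to compound 3 (0.37 log units; beyond the scatter), concerns a different group. Compound 1 carries tert-butyl on a core that differs elsewhere and gives 6 nM, which does not settle the matter. A small move, within or near the scatter, is expected in this assay. Compound 4 is therefore estimated at 7 nM, between 3 nM and 18 nM, an expected step of a 1.7-fold lower number from compound 3 to compound 4 (0.23 log units; within the scatter).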

Compound 4, inhibition constant: 5.3 nM
Estimate against measurement, compound 4: 1.3-fold (0.12 log units) above; low and high end bracket the measured number.
By their numbers in this assay, from the lowest: compounds 2, 4, 1 and 3 (each within the scatter of the next, the first and the last beyond it).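

In this assay, tert-butyl in place of cyclobutyl gives a 2.3-fold lower number from compound 3 to compound 4 (0.35 log units; beyond the scatter), so this position tells apart two groups with the same heavy-atom count, one with a ring and one without. With tert-butyl in place of 1,3-thiazol-2-yl, the result is a 1.0-fold higher number from compound 2 to compound 4 (0.02 log units; within the scatter), so these two groups cannot be told apart here. Ethyl in place of 1,1,2,2,2-pentafluoroethyl on a saturated chain carbon gives a 1.1-fold lower number from compound 1 to compound 4 (0.05 log units; within the scatter), so this change elsewhere in the molecule also has no readable effect.

No evidence here explains these steps. On these data alone, how an amine or a longer chain at this position would read remains open.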